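The source may hold more compounds than are shown below. What is called first, only, known or untested is meant among the compounds shown, and "the series" means these compounds.

In a functional assay on B16-F10 cells (Mus musculus) for antiproliferative activity, read by CCK-8 assay, with a stated time of 48 h (a lower number here means a stronger inhibitor, a higher number a weaker inhibitor), compound 1 `COc1ccc(/C=C\c2cc(OC)c(OC)c(OC)c2)cc1OCc1ccc(CNC(C)(C)C(=O)O)cc1` gives > 10000 nM, which is a limit of the assay and not a number. Compound 3 `COc1ccc(/C=C\c2cc(OC)c(OC)c(OC)c2)cc1OCc1ccc(CN2CCCCC2C(=O)O)cc1` gives > 10000 nM, likewise a limit. Compound 3 thus stands at the limit of > 10000 nM in this assay, at which 2 of the 3 values shown sit. Compound 2 `COc1ccc(/C=C\c2cc(OC)c(OC)c(OC)c2)cc1OCc1ccc(C=O)cc1`, the formyl member of the set, gives a true number of 4200 nM.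

The next step leads to compound 4 `COc1ccc(/C=C\c2cc(OC)c(OC)c(OC)c2)cc1OCc1ccc(CO)cc1`, in which hydroxy takes the place of 2-carboxypiperidin-1-yl on a saturated chain carbon bound to an aromatic carbon (hydroxy in place of 2-carboxypiperidin-1-yl on a saturated chain carbon bound to an aromatic carbon). Cut one bond further out, the change runs from (2-carboxypiperidin-1-yl)methyl to hydroxymethyl.

Going by the values given here, two measured steps bear on this change: an at least 2.3-fold lower number from compound 1 to compound 2 (0.37 log units; beyond the scatter) and an at least 2.3-fold higher number from compound 2 to compound 3 (0.37 log units; beyond the scatter). Both tie the loss of a measurable value in this assay to the presence of a carboxy-bearing amine group, while a step that the two limits leave unreadable from compound 1 to compound 3 says nothing on size. Removing that group is therefore expected to lower the number by at least a modest step, towards the reading of compound 2 at 4200 nM. The expected change is an at least 3.3-fold lower number from compound 3 to compound 4 (0.52 log units; beyond the scatter). For compound 4 the estimated value is 3000 nM, with an expected range from 800 nM to 10000 nM.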

Compound 4, half-maximal inhibitory concentration: 6600 nM
Beside the measured number, compound 4's estimate is 2.2-fold (0.34 log units) below it; the range from low to high includes it.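

Going by these compounds alone, the hydroxymethyl group of compound 4 shows that formyl is not the only group at this place to give a true number in this assay: a 1.6-fold higher number from compound 2 to compound 4 (0.20 log units; within the scatter), so the two groups cannot be told apart here. Measured against the carboxy-bearing amine groups, the result gives an at least 1.5-fold lower number from compound 3 to compound 4 (0.18 log units; that floor lies within the scatter) and an at least 1.5-fold lower number from compound 1 to compound 4 (0.18 log units; that floor lies within the scatter), and these are floors only, neither of which alone establishes a real gain. Compound 1 and compound 3 each remain at a limit of the assay and not a number: the limit of > 10000 nM in this assay, at which 2 of the 4 values shown sit.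

From the compounds shown here alone, the true size of the gain from either carboxy-bearing amine group to hydroxy therefore stays unknown, as does whether a larger step lies hidden behind those limits. Going by these compounds, it also remains open whether the loss of a measurable value follows the amine or the carboxylic acid, which a plain piperidin-1-yl without the carboxy group, or a carboxylic acid alone on the same saturated chain carbon bound to an aromatic carbon, would separate.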